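Ether Substituent Expected to Raise Maximal Response

The source may report more compounds than this note shows. Statements on the series, on what has been measured and on what is new or still open speak of the compounds shown alone.

Measured compounds:
compound 1, `CC(C)CCn1ccc(-c2ccccc2)c(C#N)c1=O`: 117%
compound 2, `CC(C)CCn1ccc(-c2ccc(OC3CCCC3)c(Cl)c2)c(C#N)c1=O`: 199%

In a functional assay on CHO cells for positive allosteric modulation of metabotropic glutamate receptor 2 (Homo sapiens), read by scintillation counting and GTPgammaS binding, with a stated time of 30 min (on this read-out higher numbers stand for larger maximal responses and lower numbers for smaller maximal responses), compound 1 gives 117%, the lowest of the two numbers. Compound 2, which carries an oxygen-linked substituent on the pendant ring, gives 199%, a number beyond the scatter higher. Compound 3, `Cc1ncccc1Oc1ccc(-c2ccn(CCC(C)C)c(=O)c2C#N)cc1`, differs from compound 1 by (2-methylpyridin-3-yl)oxy in place of hydrogen on an aromatic carbon. Within the data shown here, no measured pair with exactly this change exists, so the expectation rests on compound 2, and because compound 2 gives 199% an increase beyond the scatter is expected. Compound 3 is therefore expected to show a step of a number 53 percentage points higher from compound 1 to compound 3 (beyond the scatter), reaching an estimated 170% with a range from 120% to 220%.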

Compound 3, largest response reached (Emax), in percent of the reference or control that the assay uses: 256%
Compound 3: middle estimate off by 86 percentage points, on the low side; measured number above the stated range.
By their numbers in this assay, from the lowest: compound 1; then compound 2; then compound 3.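

In this assay, (2-methylpyridin-3-yl)oxy in place of hydrogen on an aromatic carbon, para to a large group, gives a large rise (a number 139 percentage points higher from compound 1 to compound 3 (beyond the scatter)). Among these compounds, this is the first single-place step, and it shows that this position accepts a substituent of this size with a higher maximal response. On these data alone, whether an amine, a carboxylic acid or plain phenoxy at this position would give a step of similar size remains open. No evidence at hand bears on what lies behind this step.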